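Methyl on the ring of compound 1

The source may hold more compounds than are shown below. What is called first, only, known or untested is meant among the compounds shown, and "the series" means these compounds.

For the measured compounds named here, compound 1 `Nc1ccc(C(=O)c2ccc(N)cc2)cc1` gives the only number so far in a functional assay on the whole organism for inhibition, with Mus musculus as the target, at a dose of 100 mg/kg by the oral route; on this read-out higher numbers stand for more inhibition at the one dose given (going by the name of the read-out) and lower numbers for less inhibition: compound 1 gives 95%. Compound 2 `NC(=O)Nc1ccc(C(=O)c2ccc(N)cc2)cc1` reaches only a limit of the assay, < 50%, which is the limit of < 50% in this assay, at which 1 of the 2 values shown sits. Going by the values given here, the single measured step, a number at least 45 percentage points lower from compound 1 to compound 2 (beyond the scatter), concerns a nitrogen and not an aromatic carbon. Compound 3 `Cc1cc(C(=O)c2ccc(N)cc2)ccc1N` differs from compound 1 by methyl in place of hydrogen on an aromatic carbon. Among the compounds with values here, no measured step covers such a change, so the expectation in this assay is a step within the scatter, estimated as a number 10 percentage points lower from compound 1 to compound 3 (within the scatter). Compound 3 is therefore expected to give 85%, within 60% to 98%.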

Compound 3, a percentage reported as inhibition, in the whole organism at one dose (the size of the read-out at that dose, not a potency): 100%
Beside the measured number, compound 3's estimate is 15 percentage points below it, and the stated range ends below it.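

In this assay, methyl in place of hydrogen on an aromatic carbon, ortho to an amino group, leaves the read-out within the scatter, with a number 5 percentage points higher from compound 1 to compound 3 (within the scatter) as the step. This position therefore accepts a methyl, unlike the carbamoyl change on the nitrogen, where the step is a number at least 45 percentage points lower from compound 1 to compound 2 (beyond the scatter) and compound 2 stands at a limit of the assay. Nothing in the evidence at hand bears on this result.

Open, on these data alone, is whether an ethyl, a methoxy or a carboxylic acid at this carbon would keep the read-out. Open too, as far as these compounds go, is how methyl behaves at other aromatic carbons, since a single methyl step supports no pattern.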